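The source may hold more compounds than are shown below. What is called first, only, known or untested is meant among the compounds shown, and "the series" means these compounds.

Measured in a functional assay on MCF7 cells (Homo sapiens) for inhibition, read by sulforhodamine B assay, with a stated time of 48 h; a lower number here means a stronger inhibitor of growth, a higher number a weaker inhibitor of growth:
compound 1 `COc1ccc(-c2[nH]c3ccccc3c2/C=C(\C#N)S(=O)(=O)c2ccccc2)cc1`: 398 nM
compound 2 `CC(=O)/C(=C\c1c(-c2ccccc2)[nH]c2ccccc12)S(=O)(=O)c1ccccc1`: 945 nM

Compound 2 carries the higher of the two numbers; its nearest neighbour is compound 1, and the gap between them lies beyond the scatter. Going by the values given here, no pair of measured compounds differs in a single place, so the two values can only be set side by side, with no step to read from them.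

Compound 3 `O=C(/C(=C\c1c(-c2ccccc2)[nH]c2ccccc12)S(=O)(=O)c1ccccc1)c1ccccc1` differs from compound 2 by phenyl in place of methyl on a carbonyl carbon. Among the compounds with values here, for this assay no measured step of this kind exists, and the two values available give no guidance in either direction. The expectation is therefore that the step of a 1.2-fold lower number from compound 2 to compound 3 (0.07 log units; within the scatter) stays within the scatter, with no clear direction. Compound 3 is estimated at 800 nM, with a range from 250 nM to 2500 nM.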

Compound 3, concentration for 50% growth inhibition: 5000 nM
Beside the measured number, compound 3's estimate is 6.3-fold (0.80 log units) below it; the measured number lies above the stated range.
By their numbers in this assay, from the lowest: compound 1; then compound 2; then compound 3.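

Going by these compounds alone, at the carbonyl carbon, the group placed there matters in this assay: going from acetyl to benzoyl gives a 5.3-fold higher number from compound 2 to compound 3 (0.72 log units; beyond the scatter), the first step that can be read from one change. The entering phenyl brings one six-membered aromatic ring of carbon only and no hydrogen-bond donor or acceptor, so the weaker growth inhibition comes with a change made of carbon alone. No measurement here bears on the reason for this step.

As far as these compounds go, it stays open whether the loss goes with the ring itself or simply with the added carbon, and a longer chain such as propyl on the same carbonyl carbon would separate the two. From the compounds shown here alone, an amine there, giving an amide, is equally open, and compound 1 differs from compound 2 and compound 3 in more than one place, so it gives no reading on this position.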